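This account rests on a few compounds, and the source may have more. Where it says the series, first, only, none or still open, it means among the compounds named here.

Compound 1 `COc1ccccc1Nc1nc(SCc2ccc(C(F)(F)F)cc2)nc2ccccc12` in a functional assay on MGC-803 cells (Homo sapiens) for cytotoxicity, read by MTT assay, with a stated time of 72 h (a higher number here means a weaker inhibitor, a lower number a stronger inhibitor), gives > 50000 nM, which is a limit of the assay rather than a number.
Compound 2 `FC(F)(F)c1ccc(CSc2nc(Nc3cccc(C(F)(F)F)c3)c3ccccc3n2)cc1` in this assay gives 15100 nM.

Among the compounds with values here, compound 2 therefore stands as the only compound of the pair with an actual number in this assay; compound 1 sits at the limit (the limit of > 50000 nM in this assay, at which 1 of the 2 values shown sits). Within the data shown here, the one measured step, an at least 3.3-fold lower number from compound 1 to compound 2 (0.51 log units; beyond the scatter), came from the change of 3-(trifluoromethyl)phenyl in place of 2-methoxyphenyl on a nitrogen on an aromatic ring.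

Compound 3 `FC(F)(F)c1ccc(CSc2nc(Nc3cccc(Cl)c3)c3ccccc3n2)cc1` keeps that nitrogen-bound ring but carries a smaller substituent on it: chloro in place of trifluoromethyl on an aromatic carbon. The measured step swapped the whole ring and its substitution pattern at once, so it bears only loosely on a change of one substituent at a single aromatic carbon. Among the measured compounds shown here, no measured step compares chloro with trifluoromethyl at this position. The expectation for compound 3 is therefore a number close to that of compound 2 in this assay, with a step of a 1.0-fold lower number from compound 2 to compound 3 (0.00 log units; within the scatter) that is not expected to go beyond the scatter. Compound 3 is estimated at 15000 nM, within a range from 6000 nM to 40000 nM.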

Compound 3, half-maximal inhibitory concentration: 14600 nM
Beside the measured number, compound 3's estimate is 1.0-fold (0.01 log units) above it, and the stated range covers the measured number.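

In this assay the step of a 1.0-fold lower number from compound 2 to compound 3 (0.01 log units; within the scatter) comes from chloro in place of trifluoromethyl on an aromatic carbon, so these two groups cannot be told apart at this position, even though chloro has 1 heavy atom and trifluoromethyl has 4. The earlier step changed the group on the ring and its place at once, and the new comparison an at least 3.4-fold lower number from compound 1 to compound 3 (0.53 log units; beyond the scatter) shows that 3-chlorophenyl on the nitrogen also gives a lower number than 2-methoxyphenyl, so that difference does not depend on trifluoromethyl itself. This second step can be stated only as a bound, because the value for compound 1 is a limit and not a number: the limit of > 50000 nM in this assay, at which 1 of the 3 values shown sits.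

On these data alone, it remains open whether the same aromatic carbon would accept a very different group, such as an amine or a carboxylic acid, with as little change in the number. Also open, as far as these compounds go, is how much of the difference from compound 1 comes from the methoxy group itself and how much from where it sits, which 3-methoxyphenyl on the same nitrogen could help to separate.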